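Chloro in place of trifluoromethyl: notes on compound 3

The source may hold more compounds than are shown below. What is called first, only, known or untested is meant among the compounds shown, and "the series" means these compounds.

Compound 1 `O=C(CCCCCCC(=O)Nc1cccc(F)c1)NO`: 500 nM
Compound 2 `O=C(CCCCCCC(=O)Nc1cccc(C(F)(F)F)c1)NO`: 1200 nM
Compound 3 `O=C(CCCCCCC(=O)Nc1cccc(Cl)c1)NO`: not yet measured

Within the data shown here, in a functional assay on U-937 cells (Homo sapiens) for antiproliferative activity, with a stated time of 48 h (on this read-out lower numbers stand for an effect already at smaller amounts and higher numbers for an effect only at larger amounts of compound), compound 2 gives 1200 nM, the higher of the two numbers so far. Among the measured compounds shown here, the only comparison is compound 1 at 500 nM.

The change under consideration is chloro in place of trifluoromethyl on an aromatic carbon. In words, chloro takes the place of trifluoromethyl on an aromatic carbon, meta to a large group.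

For the measured compounds named here, one measured step bears on this: a 2.4-fold higher number from compound 1 to compound 2 (0.38 log units; beyond the scatter). It is modest and involves the same trifluoromethyl group, introduced in place of fluoro. Read in reverse, it suggests that removing trifluoromethyl could bring the number down. Going by the values given here, no chloro compound has been measured, so this single step is a thin guide, and the size of any shift remains open. A modest move to a lower number is expected, no larger than the measured step and possibly within the scatter.

The estimated change is a 1.6-fold lower number from compound 2 to compound 3 (0.20 log units; within the scatter). For compound 3 the expected value is 750 nM, with an estimated range of 350 nM to 1500 nM.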

Compound 3, half-maximal effective concentration: 350 nM
Beside the measured number, compound 3's estimate is 2.1-fold (0.33 log units) above it; the measured number falls inside the stated range.
By their numbers in this assay, from the lowest: compounds 3 and 1 (each within the scatter of the next); then compound 2.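

In this assay, replacing trifluoromethyl with chloro on this aromatic carbon gives a 3.4-fold lower number from compound 2 to compound 3 (0.54 log units; beyond the scatter), so the position also responds to this second exchange, and the step is larger than the one seen earlier in the opposite direction. Chloro and fluoro are not separated at this position: the series shows a 1.4-fold lower number from compound 1 to compound 3 (0.15 log units; within the scatter), so no order can be drawn between the two halogens. Among the three compounds, compound 2 alone stands apart, with its trifluoromethyl group of 4 heavy atoms, while the halogen compounds remain together.

The compounds shown offer no measurement that explains the separation of trifluoromethyl from the two halogens. Whether an amine, a methoxy group or a carboxylic acid on the same aromatic carbon would fall with the halogens or with compound 2 remains open, as does whether a longer chain in the core would keep the same pattern among these groups.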